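The source may hold more compounds than are shown below. What is called first, only, known or untested is meant among the compounds shown, and "the series" means these compounds.

- Compound 1 `Cc1ccccc1NNC(=O)c1ccccc1NS(=O)(=O)c1cnc(O)nc1O`: > 20000 nM
- Compound 2 `O=C(NNc1ccccc1Cl)c1ccccc1NS(=O)(=O)c1cnc(O)nc1O`: > 20000 nM

Both compounds were tested in a functional assay on SGC-7901 cells (Homo sapiens) for antiproliferative activity, read by MTT assay, with a stated time of 24 h; a lower number here means a stronger inhibitor, a higher number a weaker inhibitor. Compound 1 gives > 20000 nM, which is a limit of the assay and not a number. Compound 2 likewise gives > 20000 nM, again a limit and not a number. Compound 2 therefore has no exact potency from which to measure a change.

The next compound, compound 3 `O=C(NNc1cccc(Cl)c1)c1ccccc1NS(=O)(=O)c1cnc(O)nc1O`, has the same atoms as compound 2, joined differently: 3-chlorophenyl in place of 2-chlorophenyl on an amine nitrogen. In words, 3-chlorophenyl replaces 2-chlorophenyl on an amine nitrogen, and the rest of the molecule stays the same.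

Among the measured compounds shown here, only one measured step bears on this change: a step that the two limits leave unreadable from compound 1 to compound 2. That step swaps chloro for methyl on an aromatic carbon and has no readable size, so it gives no guide to the size or direction of the next step. The working expectation in this assay is therefore no change beyond the scatter, and another limit is quite likely. The expected change is a step that the limit leaves unreadable from compound 2 to compound 3. For compound 3 the estimated value is 25000 nM, with an expected range of 9000 nM to 50000 nM.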

Compound 3, half-maximal inhibitory concentration: 10800 nM
Compound 3: middle estimate off by 2.3-fold (0.36 log units), on the high side, and the stated range covers the measured number.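

Among the compounds shown here, compound 3 is the first compound to give an exact number in this assay, 10800 nM, so this place on the amine nitrogen now has a measured reference point. With the same atoms joined differently, 3-chlorophenyl in place of 2-chlorophenyl gives an at least 1.8-fold lower number from compound 2 to compound 3 (0.26 log units; that floor lies within the scatter), and 3-chlorophenyl in place of 2-methylphenyl at the same place gives an at least 1.8-fold lower number from compound 1 to compound 3 (0.26 log units; that floor lies within the scatter). Both steps are floors rather than full sizes, each floor lies within the scatter, and so the result shows that a measurable number can be reached here without showing how large either change really is, with both floors resting on one shared limit: the limit of > 20000 nM in this assay, at which 2 of the 3 values shown sit.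

The compounds shown leave open what other groups would do at this place on the amine nitrogen, such as an unsubstituted phenyl, a methoxyphenyl or a pyridyl group. The shared core is the same in all three compounds, so they also say nothing about how changes elsewhere in the molecule would alter the number.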